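The source may hold more compounds than are shown below. What is called first, only, known or untested is meant among the compounds shown, and "the series" means these compounds.

Compound 3 `Cc1nc(N2CCC(O)(C3CCC3)CC2)nc2ccc(NC(=O)/C=C/c3ccc(Cl)cc3)cc12` gives 206 nM in an assay on CHO-K1 cells for displacement of a labelled ligand from melanin-concentrating hormone receptor 1 (Homo sapiens), read by scintillation proximity assay, with a stated time of 2 h (a higher number here means a weaker inhibitor, a lower number a stronger inhibitor), the lowest of the three numbers shown, though compound 2 sits within the scatter of it. Compound 2 `CCCC1(O)CCN(c2nc(C)c3cc(NC(=O)/C=C/c4ccc(Cl)cc4)ccc3n2)CC1` gives 245 nM, and the pair differ only by a 1.2-fold lower number from compound 2 to compound 3 (0.08 log units; within the scatter). Compound 1 `C/C(=C\C(=O)Nc1ccc2nc(N3CCC(O)CC3)nc(C)c2c1)c1ccc(Cl)cc1` gives 670 nM; its gap to compound 3 lies beyond the scatter, but the two structures differ in more than one place, so no single step can be read from them.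

Compound 4 `Cc1nc(N2CCC(O)CC2)nc2ccc(NC(=O)/C=C/c3ccc(Cl)cc3)cc12` differs from compound 3 by hydrogen in place of cyclobutyl on a saturated ring carbon. Going by the values given here, the only measured step at this ring carbon is a 1.2-fold lower number from compound 2 to compound 3 (0.08 log units; within the scatter), an exchange of one large group for another, which says nothing about losing the group altogether. Compound 1 carries the same hydrogen there but is not directly comparable. Among the compounds with values here, since the measured data give no step for this change, the expectation rests on the loss of the cyclobutyl alone and is a modestly higher number for compound 4, a 2.0-fold higher number from compound 3 to compound 4 (0.31 log units; beyond the scatter) in this assay, with wide uncertainty. Compound 4 is estimated at 420 nM, in a range from 150 nM to 1200 nM.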

Compound 4, half-maximal inhibitory concentration: 107 nM
Beside the measured number, compound 4's estimate is 3.9-fold (0.59 log units) above it; the measured number lies below the stated range.
By their numbers in this assay, from the lowest: compounds 4, 3 and 2 (each within the scatter of the next, the first and the last beyond it); then compound 1.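

Hydrogen in place of cyclobutyl on this saturated ring carbon gives a 1.9-fold lower number from compound 3 to compound 4 (0.28 log units; within the scatter) in this assay and so shows that the large group is not required there. Hydrogen in place of propyl gives a 2.3-fold lower number from compound 2 to compound 4 (0.36 log units; beyond the scatter) and is the first step at this ring carbon to lie beyond the scatter, so neither large group holds an advantage over hydrogen. Compound 4 also makes the other end of compound 1 readable as a single change, since 2-(4-chlorophenyl)ethenyl in place of 2-(4-chlorophenyl)prop-1-en-1-yl on a carbonyl carbon gives a 6.3-fold lower number from compound 1 to compound 4 (0.80 log units; beyond the scatter) in this series. Nothing given here explains these steps.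

On these data alone, it remains open whether a single methyl on this ring carbon, or an amine in place of the hydroxy group, would keep the number. Also open, as far as these compounds go, is whether the step at the carbonyl end would hold with cyclobutyl or propyl on the ring carbon.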